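The compounds below may be only part of what the source reports. "The series", "measured", "known", "first", "only" and "open" are said of these compounds alone.

Working notes on the series. Compound 1 `Cc1nc(N)sc1CCCN/C(N)=N/C(=O)NCC(C)CCc1ccccc1` gives 0.69 in a functional assay on membranes from Sf9 cells for agonist activity at histamine H2 receptor (Homo sapiens), read by scintillation counting and GTPgammaS binding, with a stated time of 90 min (a higher number here means a larger maximal response, a lower number a smaller maximal response), the highest of the three numbers recorded there. Compound 3 `N/C(=N\C(=O)NCc1ccccc1)NC1CCc2nc(N)sc2C1` comes nearest with 0.53, and compound 2 `CCCCCCNC(=O)/N=C(\N)NC1CCc2nc(N)sc2C1` lies furthest away at 0.16; both gaps to compound 1 are beyond the scatter.

Compound 4 `CCCNC(=O)/N=C(\N)NCCCc1sc(N)nc1C` has not yet been measured. It differs from compound 1 in one place: hydrogen in place of phenethyl on a saturated chain carbon bound to two saturated chain carbons. The side chain of compound 1 thus loses its aromatic end and becomes a short saturated chain.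

For the measured compounds named here, the one measured step that bears on this is a number 0.37 higher from compound 2 to compound 3 (beyond the scatter); it runs the other way, introducing an aromatic ring in place of a saturated chain on a different core, and it was large. Taking it as a guide, removing the aromatic ring from compound 1 is expected to cost a comparable amount of intrinsic activity, so a downward step a number 0.34 lower from compound 1 to compound 4 (beyond the scatter) beyond the scatter is expected. The uncertainty is considerable, since the reference step was read on the saturated bicyclic core and not on the core of compound 1.

For compound 4 the expected value in this assay is therefore 0.35, with a range from 0.15 to 0.55.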

Compound 4, intrinsic activity: the largest response reached, as a fraction of the reference agonist's: 0.79
Beside the measured number, compound 4's estimate is 0.44 below it; the whole stated range lies below it.
By their numbers in this assay, from the lowest: compound 2; then compound 3; then compounds 1 and 4 (each within the scatter of the next).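

On the core of compound 1, hydrogen in place of phenethyl on a saturated chain carbon bound to two saturated chain carbons gives a number 0.10 higher from compound 1 to compound 4 (within the scatter) in this assay. At this place, the whole phenethyl group, with its 8 heavy atoms and its six-membered aromatic ring of carbon only, can therefore leave without a step beyond the scatter, and compound 4, with no aromatic ring in its side chain, still gives 0.79. The other step on record, a number 0.37 higher from compound 2 to compound 3 (beyond the scatter), with phenyl in place of pentyl, belongs to a different core and a different change, and it does not carry over to this place on the core of compound 1. Nothing at hand accounts for this result.

As far as these compounds go, whether a longer chain, a terminal amine or a carboxylic acid at this place would keep the response in this assay remains open. It is also open whether the same loss of phenethyl would give so small a step on the core of compound 2, and the compounds shown give no means of judging that.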